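This account rests on a few compounds, and the source may have more. Where it says the series, first, only, none or still open, it means among the compounds named here.

Measured so far:
- compound 1 `O=S(=O)(NCCCNCc1ccccc1Cl)c1cc(C(F)(F)F)cc(C(F)(F)F)c1`: 13000 nM
- compound 2 `O=S(=O)(NCCCNCC1COc2ccccc2O1)c1cc(C(F)(F)F)cc(C(F)(F)F)c1`: 2500 nM

Among the measured compounds shown here, in a functional assay on Capan-2 cells (Homo sapiens) for inhibition, read by MTT assay, with a stated time of 72 h (a lower number here means a stronger inhibitor of growth, a higher number a weaker inhibitor of growth), compound 2 gives 2500 nM, the lowest of the two numbers; the only other compound, compound 1, gives 13000 nM. Compound 3 `O=S(=O)(NCCCNCc1cccc2ccccc12)c1cc(C(F)(F)F)cc(C(F)(F)F)c1` differs from compound 2 by naphthalen-1-yl in place of 2,3-dihydro-1,4-benzodioxin-2-yl on a saturated chain carbon bound to an amine nitrogen. For the measured compounds named here, the one measured step, a 5.2-fold lower number from compound 1 to compound 2 (0.72 log units; beyond the scatter), exchanged rings at the same place and was modest, but neither ring was naphthalen-1-yl, so no measured step bears directly on this change. A step of a 2.0-fold higher number from compound 2 to compound 3 (0.30 log units; within the scatter) is expected, weakening growth inhibition somewhat. Compound 3 is estimated at 5000 nM, within 1500 nM to 16000 nM.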

Compound 3, concentration for 50% growth inhibition: 2700 nM
Beside the measured number, compound 3's estimate is 1.9-fold (0.27 log units) above it, and the stated range covers the measured number.
By their numbers in this assay, from the lowest: compounds 2 and 3 (each within the scatter of the next); then compound 1.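

In this assay, the oxygen-free naphthalen-1-yl serves at this place as well as the oxygen-bearing 2,3-dihydro-1,4-benzodioxin-2-yl, with a 1.1-fold higher number from compound 2 to compound 3 (0.03 log units; within the scatter), so the ring oxygens are not required for this level of growth inhibition. The gain over 2-chlorophenyl is also not unique to compound 2, since the data show a 4.8-fold lower number from compound 1 to compound 3 (0.68 log units; beyond the scatter). Nothing available explains these results.

Going by these compounds, it remains open whether naphthalen-2-yl or unsubstituted phenyl at this place would match compound 2 and compound 3. The effect of a longer chain on the core is also unknown.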